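The compounds below may be only part of what the source reports. "The series", "measured", "known", "first", "only" and "open" are said of these compounds alone.

Working notes on the series. Compound 1 `O=C(NCc1cc(Cl)ccc1-n1cnnn1)[C@@H]1CC=NN1C(=O)[C@H](O)c1ccccc1`, compound 2 `CC(C)(C)C[C@@H](O)C(=O)N1N=CC[C@H]1C(=O)NCc1cc(Cl)ccc1-n1cnnn1`, compound 3 `O=C(NCc1cc(Cl)ccc1-n1cnnn1)[C@@H]1C[C@H]2C[C@H]2N1C(=O)[C@H](O)c1ccccc1` and compound 4 `CC(C)(C)C[C@@H](O)C(=O)N1[C@@H]2C[C@@H]2C[C@H]1C(=O)NCc1cc(Cl)ccc1-n1cnnn1` are compared; the difference between the core of compound 1 and the core of compound 3 is not broken down here. In an ADME assay on liver for metabolic stability, with Liver microsome (Homo sapiens) as the target, read by LC-MS, using microsomes (a lower number here means slower removal, a higher number faster removal of the compound), compound 1 gives < 12 mL.min-1.g-1, which is a limit of the assay (the limit of < 12 mL.min-1.g-1 in this assay, at which 1 of the 3 values shown sits). In this assay compound 2 gives 22 mL.min-1.g-1. The change neopentyl in place of phenyl on a saturated chain carbon bound to a carbonyl carbon and an oxygen on a saturated carbon made an at least 1.8-fold higher number from compound 1 to compound 2 (0.26 log units; that floor lies within the scatter). In this assay compound 3 gives < 15 mL.min-1.g-1, again a limit (the limit of < 15 mL.min-1.g-1 in this assay, at which 1 of the 3 values shown sits). Compound 4 carries the same change on the core of compound 3: neopentyl in place of phenyl on a saturated chain carbon bound to a carbonyl carbon and an oxygen on a saturated carbon. Because an at least 1.8-fold higher number from compound 1 to compound 2 (0.26 log units; that floor lies within the scatter) was seen once, a step of similar size is expected in this assay, namely an at least 1.6-fold higher number from compound 3 to compound 4 (0.22 log units; that floor lies within the scatter). Compound 4 is therefore estimated at 25 mL.min-1.g-1, expected between 12 mL.min-1.g-1 and 55 mL.min-1.g-1.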

Compound 4, intrinsic clearance in microsomes: 71 mL.min-1.g-1
Estimate against measurement, compound 4: 2.8-fold (0.45 log units) below; measured number above the stated range.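

In this assay neopentyl in place of phenyl gives an at least 4.7-fold higher number from compound 3 to compound 4 (0.67 log units; beyond the scatter), so on this core the rise in clearance stands clear of the scatter. The value of compound 3, < 15 mL.min-1.g-1, is a limit of the assay. The change raises the number on this core, but whether its size carries over unchanged from one core to the other is not shown: the same change on two cores in this assay, an at least 1.8-fold higher number (0.26 log units; that floor lies within the scatter) from compound 1 to compound 2 and an at least 4.7-fold higher number (0.67 log units; beyond the scatter) from compound 3 to compound 4; the limit leaves it open whether they differ.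

The compounds shown leave open how the step behaves on any further core. They also leave open whether a cyclohexyl group or an amine in the same place would track phenyl or neopentyl, which would separate the loss of the aromatic ring from the chain itself.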